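Adding Chloro and Methyl to the Naphthalene Ether

The source may hold more compounds than are shown below. What is called first, only, known or untested is meant among the compounds shown, and "the series" means these compounds.

Among the compounds with values here, compound 1 `Cc1cc(S(N)(=O)=O)ccc1NC(=O)COc1ccc(F)cc1Oc1ccc2ccccc2c1` is the only compound with a number in an ADME assay on C8166 cells (Homo sapiens) for cytotoxicity, read by MTT assay (on this read-out lower numbers stand for higher toxicity in this test and higher numbers for lower toxicity in this test), where compound 1 gives 68600 nM. Compound 2 `Cc1cc(S(N)(=O)=O)ccc1NC(=O)COc1ccc(Cl)cc1Oc1ccc2cc(C#N)ccc2c1` reaches only a limit of the test in this assay, namely > 383000 nM, and that is the limit of > 383000 nM in this assay, at which 1 of the 2 values shown sits. Compound 3 `Cc1cc(S(N)(=O)=O)ccc1NC(=O)COc1ccc(F)cc1Oc1c(C)cc2ccccc2c1Cl` differs from compound 1 by 1-chloro-3-methylnaphthalen-2-yl in place of naphthalen-2-yl on an oxygen on an aromatic ring. Within the data shown here, no measured pair shows how much such a change moves the result, so the step in this assay is expected to be small, if anything toward a lower number. Compound 3 is estimated at 50000 nM, between 20000 nM and 150000 nM, an expected step of a 1.4-fold lower number from compound 1 to compound 3 (0.14 log units; within the scatter).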

Compound 3, half-maximal cytotoxic concentration: 55600 nM
Compound 3: middle estimate off by 1.1-fold (0.05 log units), on the low side; low and high end bracket the measured number.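

Within the data shown here, this is the first comparison in this assay in which only this ring changes: swapping naphthalen-2-yl for 1-chloro-3-methylnaphthalen-2-yl gives a 1.2-fold lower number from compound 1 to compound 3 (0.09 log units; within the scatter). So, at this position, adding the chlorine and the methyl together leaves the read-out with no change that this test can separate from ordinary scatter. Nothing shown gives a reason for this.

Going by these compounds, the chlorine and the methyl arrive together, so what each does alone remains open. So does the effect of an amine or a carboxylic acid on this naphthalene.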